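Adding a third methoxy to compound 2

The source may report more compounds than this note shows. Statements on the series, on what has been measured and on what is new or still open speak of the compounds shown alone.

In a functional assay on MCF7 cells (Homo sapiens) for antiproliferative activity (on this read-out lower numbers stand for stronger inhibition of growth and higher numbers for weaker inhibition of growth), compound 1 `COc1ccc(-c2nc3cc(F)ccc3s2)cc1OC` gives < 0.1 nM as a limit of the assay and not a number. Going by the values given here, compound 2 `COc1cc(OC)cc(-c2nc3cc(F)ccc3s2)c1` gives 1230 nM and so holds the only true number so far. Compound 3 `COc1cc(-c2nc3cc(F)ccc3s2)cc(OC)c1OC` comes from compound 2 by methoxy in place of hydrogen on an aromatic carbon with methoxy in place of hydrogen on an aromatic carbon. Among the compounds with values here, no measured step covers this change. The expectation rests on compound 1 with its limit < 0.1 nM in that all its methoxy groups recur in compound 3. An estimated step of a 12-fold lower number from compound 2 to compound 3 (1.09 log units; beyond the scatter) is expected towards stronger inhibition of growth and beyond the scatter. Compound 3 is expected at 100 nM in a range from 1 nM to 3000 nM on this estimate.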

Compound 3, concentration for 50% growth inhibition: 1.9 nM
The estimate for compound 3 lay 53-fold (1.72 log units) above the measured number, and the stated range covers the measured number.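

In this assay, a methoxy group entering on an aromatic carbon ortho to two methoxy groups and para to a large group gives a 650-fold lower number from compound 2 to compound 3 (2.81 log units; beyond the scatter), so this position strongly affects the read-out in the presence of those two methoxy groups. The same kind of exchange, read from the other parent, runs the opposite way, with an at least 19-fold higher number from compound 1 to compound 3 (1.27 log units; beyond the scatter), so methoxy in place of hydrogen has no single direction across these compounds. That second step rests on a limit of the assay and not a number, held by compound 1: the limit of < 0.1 nM in this assay, at which 1 of the 3 values shown sits.

From the compounds shown here alone, whether the gain in compound 3 is specific to methoxy stays open, since hydroxyl, ethoxy or an amine at this position would be needed to tell. Also open, going by these compounds, is whether this position responds the same way without the two methoxy groups.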